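This account rests on a few compounds, and the source may have more. Where it says the series, first, only, none or still open, it means among the compounds named here.

Series sharing the core of compound 1 `Brc1ccc2[nH]cc(C(c3ccccc3)c3c[nH]c4ccc(Br)cc34)c2c1`, with the group on the saturated chain carbon bound to two aromatic carbons varied. In a functional assay on A549 cells (Homo sapiens) for inhibition, read by MTT assay, with a stated time of 48 h (on this read-out higher numbers stand for weaker inhibition and lower numbers for stronger inhibition), compound 1 gives 7500 nM. Compound 2 `Oc1ccc(C(c2c[nH]c3ccc(Br)cc23)c2c[nH]c3ccc(Br)cc23)cc1` gives 9000 nM in this assay and stands second highest of the three numbers; the step of a 1.2-fold higher number from compound 1 to compound 2 (0.08 log units; within the scatter) is within the scatter. Compound 3 `COc1ccc(C(c2c[nH]c3ccc(Br)cc23)c2c[nH]c3ccc(Br)cc23)cc1OC` gives 12000 nM in this assay; the steps of a 1.6-fold higher number from compound 1 to compound 3 (0.20 log units; within the scatter) and a 1.3-fold higher number from compound 2 to compound 3 (0.12 log units; within the scatter) are likewise within the scatter, so the three measured compounds are not separated from one another.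

Compound 4 `CCCCCCCC(c1c[nH]c2ccc(Br)cc12)c1c[nH]c2ccc(Br)cc12` has not yet been measured. Its change from compound 2: heptyl in place of 4-hydroxyphenyl on a saturated chain carbon bound to two aromatic carbons. The three measured steps each swap one aromatic substituent for another at this carbon, and none of them moved the number beyond the scatter. Going by the values given here, no measured step replaces the ring with a chain, so these steps bear on the change only in showing that variation at this position has so far produced no step beyond the scatter. Among the compounds with values here, the expected step of no change at the digits printed from compound 2 to compound 4 (within the scatter) is accordingly none beyond the scatter, with a wide range since no measured pair covers a chain at this place. Compound 4 is estimated at 9000 nM in this assay, range 3000 nM to 27000 nM.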

Compound 4, half-maximal inhibitory concentration: 3500 nM
Compound 4: middle estimate off by 2.6-fold (0.41 log units), on the high side; low and high end bracket the measured number.
By their numbers in this assay, from the lowest: compound 4; then compounds 1, 2 and 3 (each within the scatter of the next).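

In this assay, going by these compounds alone, heptyl on the saturated chain carbon bound to two aromatic carbons is the first change at this place to move the number beyond the scatter, and the shift is modest against each aromatic group (a 2.6-fold lower number from compound 2 to compound 4 (0.41 log units; beyond the scatter); a 2.1-fold lower number from compound 1 to compound 4 (0.33 log units; beyond the scatter); a 3.4-fold lower number from compound 3 to compound 4 (0.54 log units; beyond the scatter)). The position therefore responds to the kind of group it carries, although the three aromatic groups are not separated from one another, and compound 4 is the strongest of the four in this assay. An aromatic ring at this carbon is thus not needed for inhibition at this level in this series, since heptyl has no ring and no hydrogen-bond donor or acceptor, but nothing at hand explains the lower number.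

The compounds shown leave open whether the ring's absence or the chain itself accounts for the step, which a cyclohexyl group at the same carbon could help to separate. They also leave open how the number follows chain length, from a propyl group to a longer chain such as dodecyl, and what an amine or a carboxylic acid at the end of the heptyl chain would do.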